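This account rests on a few compounds, and the source may have more. Where it says the series, first, only, none or still open, it means among the compounds named here.

In a functional assay on Huh-7 cells (Homo sapiens) for inhibition, read by CCK-8 assay, with a stated time of 72 h (a lower number here means a stronger inhibitor, a higher number a weaker inhibitor), compound 1 `O=C(/C=C/c1cccnc1)NCCCCCCc1ccc(S(=O)(=O)Nc2ccccc2)cc1` gives 112 nM while compound 2 `Cc1ccccc1NS(=O)(=O)c1cccc(CCCCCCNC(=O)/C=C/c2cccnc2)c1` gives 0.525 nM and so stands lowest of the two, with the gap between them well beyond the usual scatter. Compound 3 `O=C(/C=C/c1cccnc1)NCCCCCCc1cccc(S(=O)(=O)Nc2ccc(F)c(Cl)c2)c1` has yet to be measured. It carries 3-chloro-4-fluorophenyl in place of 2-methylphenyl on a sulfonamide nitrogen, and the counted difference reads 3-chloro-4-fluorophenyl in place of 2-methylphenyl on a sulfonamide nitrogen when set against compound 2. For the measured compounds named here, no measured pair isolates this change, so the data offer no direct guide to its size. Compound 2 sits so low at 0.525 nM that a move toward a higher number, meaning a weaker inhibitor, is expected, probably beyond the scatter. The expected change is a 5.7-fold higher number from compound 2 to compound 3 (0.76 log units; beyond the scatter) in this assay as a rough estimate. For compound 3 the estimated value is 3 nM with an expected range from 0.4 nM to 25 nM as the span of likely results.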

Compound 3, half-maximal inhibitory concentration: 39.4 nM
Compound 3: the middle estimate sits 13-fold (1.12 log units) below what was measured; the measured number lies above the stated range.
By their numbers in this assay, from the lowest: compound 2; then compound 3; then compound 1.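

In this assay, exchanging 2-methylphenyl for 3-chloro-4-fluorophenyl on the sulfonamide nitrogen brings a 75-fold higher number from compound 2 to compound 3 (1.88 log units; beyond the scatter), and this is the only pair shown that differs in one place. For the compounds shown here, it therefore gives the first direct reading of this position: with the rest of the molecule unchanged, the identity of the aryl group on that nitrogen matters greatly for this read-out. Of these two groups, 2-methylphenyl gives the far stronger inhibitor, while compound 3 keeps a low nanomolar-range value of 39.4 nM rather than losing activity altogether.

The compounds shown leave open whether 3-chlorophenyl or 4-fluorophenyl alone would give the same step, and whether a 2-chlorophenyl or 2-methoxyphenyl group would match 2-methylphenyl. No measurement shown accounts for the size of this step.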